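A Chloro Substituent and Tolerance in Vero Cells

The source may report more compounds than this note shows. Statements on the series, on what has been measured and on what is new or still open speak of the compounds shown alone.

Measured so far:
compound 1 `O=C(Nc1ccccc1)c1ccc([N+](=O)[O-])o1` gives 6700 nM.
compound 2 `O=C(Nc1ccc(Cl)cc1)c1ccc([N+](=O)[O-])o1` gives 1500 nM.
compound 3 `CC(C)(NC(=O)c1ccc([N+](=O)[O-])o1)c1ccccc1` gives > 180000 nM, which is a limit of the assay, not a number.

In an ADME assay on Vero cells (Chlorocebus sabaeus) for cytotoxicity, read by MTT assay, with a stated time of 48 h (a higher number here means that more compound is tolerated, a lower number that less compound is tolerated), the change chloro in place of hydrogen on an aromatic carbon produced the step of a 4.5-fold lower number from compound 1 to compound 2 (0.65 log units; beyond the scatter). Compound 3 reached only (the limit of > 180000 nM in this assay, at which 1 of the 3 values shown sits). How the core of compound 3 differs from the core of compound 1 is not broken down here. Compound 4 `CC(C)(NC(=O)c1ccc([N+](=O)[O-])o1)c1ccc(Cl)cc1` carries the same change, (chloro in place of hydrogen on an aromatic carbon), at the same place. In this assay the expected step is an at least 2.2-fold lower number from compound 3 to compound 4 (0.35 log units; beyond the scatter), resting on the measured step of a 4.5-fold lower number from compound 1 to compound 2 (0.65 log units; beyond the scatter). Compound 4 is therefore estimated at 80000 nM, most likely between 20000 nM and 300000 nM. Compound 4 may again be reported only as a limit because compound 3 sits at the limit of > 180000 nM in this assay, at which 1 of the 3 values shown sits.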

Compound 4, half-maximal cytotoxic concentration: 81000 nM
The estimate for compound 4 lay 1.0-fold (0.01 log units) below the measured number, and the stated range covers the measured number.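

Chloro in place of hydrogen on an aromatic carbon gives an at least 2.2-fold lower number from compound 3 to compound 4 (0.34 log units; beyond the scatter) in this assay, so on this second core the number moves the same way as on the first. Compound 3 gives > 180000 nM, which is a limit of the assay and not a number. The direction of the change therefore carries over between these two cores, but whether its size also carries over stays unsettled: the same change on two cores in this assay, a 4.5-fold lower number (0.65 log units; beyond the scatter) from compound 1 to compound 2 and an at least 2.2-fold lower number (0.34 log units; beyond the scatter) from compound 3 to compound 4; the limit leaves it open whether they differ

The compounds shown test only chloro, and only at this one place on the ring, on two cores. They leave open whether another group there, such as fluoro, methoxy or a carboxylic acid, would lower the number in the same way.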